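A few compounds are considered here, and "the series" means these few. Any claim that something is new, unique, unknown or untested is made for them only; others in the source may bear on it.

Compound 1 `Cc1cccc(Cn2cc(COc3ccc4c(=O)ccoc4c3)nn2)c1` sits at the better end of the pair measured so far: in a functional assay on MDA-MB-231 cells (Homo sapiens) for cytotoxicity, read by MTT assay, with a stated time of 48 h (a lower number here means a stronger inhibitor, a higher number a weaker inhibitor), compound 1 gives 16000 nM. Compound 2 `O=c1ccoc2cc(OCc3cn(Cc4cccc(Br)c4)nn3)ccc12` differs from it by a bromo in place of methyl on an aromatic carbon. In this assay compound 2 reaches only a limit, > 100000 nM. For the measured compounds named here, that step, an at least 6.2-fold higher number from compound 1 to compound 2 (0.79 log units; beyond the scatter), is the one measured comparison that bears on what follows, and it leaves compound 2 at the edge of what the assay reports, namely the limit (the limit of > 100000 nM in this assay, at which 1 of the 2 values shown sits).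

Compound 3 `Cc1ccccc1Cn1cc(COc2ccc3c(=O)ccoc3c2)nn1` differs from compound 2 by 2-methylphenyl in place of 3-bromophenyl on a saturated chain carbon bound to an aromatic nitrogen. This change undoes the bromo and brings a methyl back, so a lower number than compound 2 is expected, about as large as the measured step in the other direction. Compound 3 is therefore estimated at 25000 nM in this assay, within 8000 nM to 100000 nM, an expected step of an at least 4.0-fold lower number from compound 2 to compound 3 (0.60 log units; beyond the scatter).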

Compound 3, half-maximal inhibitory concentration: > 100000 nM
Compound 3 was reported as a limit; the forecaster's own chance of this, stated with the estimate: 25%; middle value at least 4.0-fold (0.60 log units) from the limit.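

Exchanging 3-methylphenyl for 2-methylphenyl on a saturated chain carbon bound to an aromatic nitrogen gives an at least 6.2-fold higher number from compound 1 to compound 3 (0.79 log units; beyond the scatter) in this assay, so a methyl on the phenyl ring does not by itself keep the number at the level of compound 1. Compound 3 reaches only a limit, > 100000 nM. The step between compound 2 and compound 3 cannot be read, and compound 1 remains the only one of the three with a value that is a number, the others sitting at the edge of what the assay reports: the limit of > 100000 nM in this assay, at which 2 of the 3 values shown sit.

On these data alone, how far compound 2 and compound 3 lie beyond that limit stays open, and so does whether they differ at all. Also open, as far as these compounds go, is whether an amine or a carboxylic acid on the phenyl ring, or a longer chain in place of the single saturated carbon, would give a number at all.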